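Working notes: removing the hydroxy from compound 2

The compounds below may be only part of what the source reports. "The series", "measured", "known", "first", "only" and "open" are said of these compounds alone.

- compound 1 `CCCCCC[C@@H](O)C/C=C\CCCCCCCC(=O)N[C@@H](C)c1ccccc1`: 11.7 ug/mL
- compound 2 `CCCCCC[C@@H](O)C/C=C\CCCCCCCC(=O)N1CCOCC1`: 38.5 ug/mL

In a functional assay on PC-3 cells (Homo sapiens) for antiproliferative activity, read by sulforhodamine B assay, with a stated time of 48 h (a lower number here means a stronger inhibitor of growth, a higher number a weaker inhibitor of growth), compound 2 holds the higher of the two numbers, which makes it the weaker inhibitor of growth of this pair. The gap is a modest one, a 3.3-fold higher number from compound 1 to compound 2 (0.52 log units; beyond the scatter). Compound 3 `CCCCCCCC/C=C\CCCCCCCC(=O)N1CCOCC1` has not yet been measured. Its structure departs from compound 2 as follows: hydrogen in place of hydroxy on a saturated chain carbon bound to two saturated chain carbons. In words, this is hydrogen in place of hydroxy on a saturated chain carbon bound to two saturated chain carbons.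

For the measured compounds named here, only one measured step exists, and it lies elsewhere, with morpholin-4-yl in place of (1-phenylethyl)amino on a carbonyl carbon. Going by the values given here, no measured pair shows the effect of losing the hydroxy, so that step serves only as a rough gauge of size. Compound 2 sits a 3.3-fold higher number from compound 1 to compound 2 (0.52 log units; beyond the scatter), and a change no larger than this is expected in this assay. The direction is open, with a slight lean to a higher number and most likely nothing beyond the scatter. The expected change is a 1.2-fold higher number from compound 2 to compound 3 (0.07 log units; within the scatter). For compound 3 the estimated value is 45 ug/mL, with an expected range from 20 ug/mL to 95 ug/mL.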

Compound 3, concentration for 50% growth inhibition: 5.2 ug/mL
Compound 3: the middle estimate sits 8.7-fold (0.94 log units) above what was measured, outside the stated range (below it).
By their numbers in this assay, from the lowest: compound 3; then compound 1; then compound 2.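

In this assay, for the compounds shown here, replacing the hydroxy with hydrogen on a saturated chain carbon bound to two saturated chain carbons gives a 7.4-fold lower number from compound 2 to compound 3 (0.87 log units; beyond the scatter), the first measured step at this position, and it runs towards stronger inhibition of growth. The hydroxy is therefore not required for activity in the morpholin-4-yl amide, where compound 3, carrying heptyl in place of 1-hydroxyheptyl, reaches 5.2 ug/mL. No supporting data are available to explain this change.

From the compounds shown here alone, the finding rests on a single matched pair, so it remains open whether the same replacement would move the number in the same direction in the (1-phenylethyl)amino amide of compound 1. Also open, going by these compounds, is how this chain carbon would respond to a methoxy, a ketone or an amine in place of the hydroxy, and whether the morpholin-4-yl amide would keep its level of activity with a longer chain or with a carboxylic acid in place of the amide.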